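Ethoxy for chloro on the weaker aniline-type compound

The compounds below may be only part of what the source reports. "The series", "measured", "known", "first", "only" and "open" are said of these compounds alone.

Measured in a functional assay on MOLT-4 cells (Homo sapiens) for antiproliferative activity, with a stated time of 48 h; on this read-out lower numbers stand for stronger inhibition and higher numbers for weaker inhibition:
compound 1 `C=C(Br)C(=O)Nc1ccc(/C=C/C(=O)c2ccc(Cl)cc2)cc1`: 810 nM
compound 2 `C=C(Br)C(=O)Nc1ccc(/C=C/C(=O)c2ccc(OCC)cc2)cc1`: 610 nM
compound 3 `Nc1ccc(/C=C/C(=O)c2ccc(Cl)cc2)cc1`: 7800 nM

Compound 3 has the highest number of the three. Hydrogen in place of (1-bromoethenyl)carbonyl on the nitrogen goes with a 9.6-fold higher number from compound 1 to compound 3 (0.98 log units; beyond the scatter). Compound 4 `CCOc1ccc(C(=O)/C=C/c2ccc(N)cc2)cc1` has ethoxy in place of chloro on an aromatic carbon, para to a large group: ethoxy in place of chloro on an aromatic carbon. For the measured compounds named here, the only measured step with this exchange is a 1.3-fold lower number from compound 1 to compound 2 (0.12 log units; within the scatter), and both of its compounds keep the (1-bromoethenyl)carbonyl. Going by the values given here, no measured pair tests the exchange without that group. Even so, no step beyond the scatter is expected in this assay. The estimated change is a 1.3-fold lower number from compound 3 to compound 4 (0.11 log units; within the scatter). The estimate for compound 4 is 6000 nM, with an expected range of 2500 nM to 14000 nM.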

Compound 4, half-maximal inhibitory concentration: 11000 nM
For compound 4 the middle estimate is 1.8-fold (0.26 log units) below the measured one, within the range that was stated.
By their numbers in this assay, from the lowest: compounds 2 and 1 (each within the scatter of the next); then compounds 3 and 4 (each within the scatter of the next).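

Without the (1-bromoethenyl)carbonyl on the nitrogen, ethoxy in place of chloro in this assay goes with a 1.4-fold higher number from compound 3 to compound 4 (0.15 log units; within the scatter), so at this position the exchange stays within the scatter with or without that group: the same change on two cores in this assay, a 1.3-fold lower number (0.12 log units; within the scatter) from compound 1 to compound 2 and a 1.4-fold higher number (0.15 log units; within the scatter) from compound 3 to compound 4, 1.9-fold (0.27 log units) apart, within the scatter of two such steps. Hydrogen in place of the (1-bromoethenyl)carbonyl now also reads on the ethoxy core, as an 18-fold higher number from compound 2 to compound 4 (1.26 log units; beyond the scatter), and the higher number holds on both cores: the same change on two cores in this assay, a 9.6-fold higher number (0.98 log units; beyond the scatter) from compound 1 to compound 3 and an 18-fold higher number (1.26 log units; beyond the scatter) from compound 2 to compound 4, 1.9-fold (0.27 log units) apart, within the scatter of two such steps.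

From the compounds shown here alone, whether a hydroxyl, a dimethylamino group or a carboxylic acid at this position would also stay within the scatter remains open. So does whether a plain acetyl on the nitrogen would give numbers like those of compound 1 and compound 2.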